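From Chloro to Methoxy on the Aryl Ether

The source may report more compounds than this note shows. Statements on the series, on what has been measured and on what is new or still open speak of the compounds shown alone.

In a functional assay on HepG2 cells (Homo sapiens) for antiproliferative activity, read by MTT assay, with a stated time of 72 h (on this read-out lower numbers stand for stronger inhibition and higher numbers for weaker inhibition), compound 1 `NC1=NC2(CCSCC2)N(OCCCOc2cc(Cl)c(Cl)cc2Cl)C(N)=N1` gives > 100000 nM as a limit of the assay and not as a number. Among the measured compounds shown here, compound 2 `NC1=NC2(CCSCC2)N(OCCCOc2ccc(Cl)cc2)C(N)=N1` gives 1100 nM in this assay and holds the only actual number so far. For the measured compounds named here, one measured step bears on the next change: an at least 90-fold lower number from compound 1 to compound 2 (1.95 log units; beyond the scatter) is large and beyond the scatter, and it came with 4-chlorophenyl in place of 2,4,5-trichlorophenyl. Compound 3 `COc1ccc(OCCCON2C(N)=NC(N)=NC23CCSCC3)cc1` differs from compound 2 by methoxy in place of chloro on an aromatic carbon and so carries methoxy in place of chloro on an aromatic carbon. The earlier step of an at least 90-fold lower number from compound 1 to compound 2 (1.95 log units; beyond the scatter) shows that this aryl group can matter a great deal, but it is a different exchange and sets no size here. The expected change is small, leaning toward weaker inhibition, an estimated 1.6-fold higher number from compound 2 to compound 3 (0.21 log units; within the scatter) with wide margins. Compound 3 is estimated at 1800 nM (range 450 nM to 8000 nM).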

Compound 3, half-maximal inhibitory concentration: 880 nM
Estimate against measurement, compound 3: 2.0-fold (0.31 log units) above, within the range that was stated.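

In this assay, methoxy in place of chloro on an aromatic carbon gives a 1.3-fold lower number from compound 2 to compound 3 (0.10 log units; within the scatter), so compound 2 and compound 3 cannot be told apart and this position takes either group without a change beyond the scatter. The large step also appears with this second group, as an at least 110-fold lower number from compound 1 to compound 3 (2.05 log units; beyond the scatter), so it does not depend on chloro at this position in the lower-number compound. Compound 1 sits at a limit of the assay and not at a number: the limit of > 100000 nM in this assay, at which 1 of the 3 values shown sits.

The compounds shown leave open whether an amine or a carboxylic acid at this position would also stay within the scatter of compound 2. They also leave open which chloro group of the 2,4,5-trichlorophenyl group in compound 1 carries the large step.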